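A Methoxy Added to the Benzyl Group of Compound 1

A few compounds are considered here, and "the series" means these few. Any claim that something is new, unique, unknown or untested is made for them only; others in the source may bear on it.

Of the compounds shown here, three from one series have been measured in a functional assay on CCRF-CEM cells (Homo sapiens) for inhibition, read by cell counting, with a stated time of 3 days; on this read-out lower numbers stand for stronger inhibition and higher numbers for weaker inhibition. Compound 1 `C=C(Br)C(=O)Nc1cccc(-c2cn3nc(Cc4ccccc4)sc3n2)c1` gives 4200 nM in this assay. Compound 2 `Nc1cccc(-c2cn3c(-c4ccc(Cl)cc4)csc3n2)c1` gives 21000 nM in this assay, and compound 3 `C=C(Br)C(=O)Nc1cccc(-c2cn3c(-c4ccccc4)csc3n2)c1` gives 2800 nM in this assay. Compound 1 thus stands second highest of the three numbers: its number and that of compound 3 lie within the usual scatter, so no order between them can be read, whereas compound 2 sits beyond the scatter with a clearly higher number, that is, weaker inhibition. Among the compounds with values here, no pair among the measured compounds differs in only one place, so no single-change step can be drawn from them.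

Compound 4 `C=C(Br)C(=O)Nc1cccc(-c2cn3nc(Cc4ccc(OC)cc4)sc3n2)c1` has not yet been measured in this assay. It differs from compound 1 by methoxy in place of hydrogen on an aromatic carbon. Within the data shown here, none of the measured compounds shows what a methoxy at this position does, so the expectation rests on the small size of the addition alone. A step of no more than the scatter, in either direction, is expected. The estimate for compound 4 is therefore 3500 nM, with a range from 1200 nM to 10000 nM, which corresponds to an expected step of a 1.2-fold lower number from compound 1 to compound 4 (0.08 log units; within the scatter).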

Compound 4, half-maximal inhibitory concentration: 2300 nM
The estimate for compound 4 lay 1.5-fold (0.18 log units) above the measured number; measured number inside the range.
By their numbers in this assay, from the lowest: compounds 4, 3 and 1 (each within the scatter of the next); then compound 2.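

In this assay, the change from benzyl to 4-methoxybenzyl gives a 1.8-fold lower number from compound 1 to compound 4 (0.26 log units; within the scatter), so the step cannot be told apart from repeated measurement. The earlier compounds shown here offered no single-change step at all, and this first one shows that the benzyl group of compound 1 can carry a methoxy in place of hydrogen, on an aromatic carbon para to a large group, without a step beyond the scatter: inhibition in this read-out is kept and neither clearly gained nor clearly lost at this place. Nothing at hand explains the result or tells what the added group does there.

A single small addition says little about how much this position tolerates, and the compounds shown leave open whether a larger or differently built group, such as an amine, a carboxylic acid or a longer chain in the same place, would give a step beyond the scatter. They also leave open whether a methoxy elsewhere on the same ring would behave as this one does, and whether the same addition would give a similar step on a different core.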